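Vinyl for ethynyl on the amide carbonyl of compound 1

The source may hold more compounds than are shown below. What is called first, only, known or untested is meant among the compounds shown, and "the series" means these compounds.

Of the compounds shown here, two have been measured in a functional assay on KYSE-450 cells (Homo sapiens) for inhibition, read by MTT assay, with a stated time of 48 h; on this read-out lower numbers stand for stronger inhibition and higher numbers for weaker inhibition. Compound 1 `C#CC(=O)N(Cc1ccc(OC)c(O)c1)c1cc(OC)c(OC)c(OC)c1` gives 570 nM in this assay, the lowest of the two numbers. Compound 2 `COc1ccc(N(Cc2cc(OC)c(OC)c(OC)c2)C(=O)CCl)cc1O`, which carries a different amide and a different arrangement of its two aryl groups, gives 29800 nM in this assay, a gap to compound 1 that lies well beyond the scatter. Among the measured compounds shown here, no pair differing in a single place has been measured yet, so nothing in the numbers so far isolates the contribution of the amide group.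

Compound 3 `C=CC(=O)N(Cc1ccc(OC)c(O)c1)c1cc(OC)c(OC)c(OC)c1` is the next compound to be measured in this assay. Relative to compound 1 it differs only at the carbonyl carbon: vinyl in place of ethynyl on a carbonyl carbon.

Expectation: the step from compound 1 to compound 3 in this assay is estimated to be small and directed toward a higher number, at most slightly beyond the scatter, as a 1.9-fold higher number from compound 1 to compound 3 (0.29 log units; within the scatter). Compound 3 is thus expected to give about 1100 nM in this assay. The plausible range for compound 3 is estimated to run from 300 nM to 4000 nM.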

Compound 3, half-maximal inhibitory concentration: 160 nM
Estimate against measurement, compound 3: 6.9-fold (0.84 log units) above; measured number below the stated range.
By their numbers in this assay, from the lowest: compound 3; then compound 1; then compound 2.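

In this assay, among the compounds shown here, the first pair of the series differing in one place gives a 3.6-fold lower number from compound 1 to compound 3 (0.55 log units; beyond the scatter) and so shows that the group on the carbonyl carbon bears on the number, with vinyl ahead of ethynyl while the rest of compound 1 stays fixed. Both groups have two carbons and neither brings a ring, a charge, a hydrogen-bond donor or a hydrogen-bond acceptor, so the step goes with a double bond replacing a triple bond outside aromatic rings and not with any change in these counts. No measurement at hand bears on why the number moves with this change.

As far as these compounds go, whether an unsaturated group is needed at this position stays open, and a saturated ethyl group on the same carbonyl carbon would test this directly against compound 3. Also open, from the compounds shown here alone, is how far the vinyl group tolerates extension, as with a longer 1-propenyl chain, and whether the same step would appear with the two aryl groups in the other arrangement.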